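Ethoxycarbonyl to methoxycarbonyl on a compound at the limit

The source may hold more compounds than are shown below. What is called first, only, known or untested is meant among the compounds shown, and "the series" means these compounds.

Among the measured compounds shown here, in a functional assay on PC-3 cells (Homo sapiens) for antiproliferative activity, with a stated time of 48 h (on this read-out higher numbers stand for weaker inhibition and lower numbers for stronger inhibition), compound 1 (`CCN(CC)c1ccc(-c2ccc(C(=O)OC)cc2)nn1`) gives 90 nM as the only true number so far. Compound 2 (`CCOC(=O)c1ccc(-c2ccc(N(C)C)nn2)cc1`) reads > 25000 nM in this assay as a limit of the assay and not a number. From the compounds shown here alone, its exact standing is unknown, and any step from it can only be judged against that limit.

Compound 3 (`COC(=O)c1ccc(-c2ccc(N(C)C)nn2)cc1`) changes compound 2 at a single place (hydrogen in place of methyl on a saturated chain carbon bound to an oxygen next to a carbonyl group): hydrogen in place of methyl on a saturated chain carbon bound to an oxygen next to a carbonyl group, so that ethoxycarbonyl becomes methoxycarbonyl. Compound 3 thereby ends in methoxycarbonyl, as does compound 1, which gives 90 nM in this assay for comparison. For the measured compounds named here, no measured step isolates this change, so the expectation is loose. The expected step (an at least 8.3-fold lower number from compound 2 to compound 3 (0.92 log units; beyond the scatter)) in this assay runs toward stronger inhibition and beyond the scatter, though a reading at the limit remains possible. For compound 3 the estimated value is 3000 nM with an expected range from 300 nM to 25000 nM in this series.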

Compound 3, half-maximal inhibitory concentration: > 25000 nM
Compound 3: no number, only a limit; the forecaster's own chance of this, stated with the estimate: 30%; middle value at least 8.3-fold (0.92 log units) from the limit.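

In this assay compound 3 reads > 25000 nM, a limit of the assay and not a number, so methoxycarbonyl in place of ethoxycarbonyl brings no measurable reading to the dimethylamino compound, and the step from compound 2 cannot be read. Compound 3 also provides a comparison at a single place with methoxycarbonyl held fixed: dimethylamino in place of diethylamino on an aromatic carbon gives an at least 270-fold higher number from compound 1 to compound 3 (2.44 log units; beyond the scatter). The amino group is thus the site of the only readable difference so far, while any differences among the compounds at the limit stay hidden: the limit of > 25000 nM in this assay, at which 2 of the 3 values shown sit.

From the compounds shown here alone, it remains open how ethoxycarbonyl behaves alongside diethylamino, a pairing that could give the change at this position a readable size away from the limit. Going by these compounds, it is also open whether a mixed ethyl and methyl amine falls between the two amino groups, and whether a longer chain such as dipropylamino keeps the reading of compound 1 in this assay.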